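Same change on two cores: expecting compound 4

The compounds below may be only part of what the source reports. "The series", "measured", "known", "first", "only" and "open" are said of these compounds alone.

Measured in a functional assay on PANC-1 cells (Homo sapiens) for cytotoxicity, read by MTT assay, with a stated time of 48 h, in the presence of a further agent that is not named here; on this read-out lower numbers stand for stronger inhibition and higher numbers for weaker inhibition:
- compound 1 `O=C(c1ccc2cccc(OCc3ccc(B(O)O)cc3)c2n1)N1CCC(Oc2no[n+]([O-])c2S(=O)(=O)c2ccccc2)CC1` gives 2690 nM
- compound 2 `CC1(C)OB(c2ccc(COc3cccc4ccc(C(=O)N5CCC(Oc6no[n+]([O-])c6S(=O)(=O)c6ccccc6)CC5)nc34)cc2)OC1(C)C` gives 3470 nM
- compound 3 `O=C(NCCCOc1no[n+]([O-])c1S(=O)(=O)c1ccccc1)c1ccc2cccc(OCc3ccc(B(O)O)cc3)c2n1` gives 1690 nM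

Compound 1 and compound 3 share much of their structure, but the difference between the two cores is not broken down here. Among the three, compound 3 has the lowest number, and its gap to compound 1 lies within the scatter, so no order between them can be claimed; its gap to compound 2 lies beyond it.

From compound 1 to compound 2 one change is made: a group of 9 heavy atoms (6 carbon, 1 boron, 2 oxygen; one five-membered non-aromatic ring with 3 hetero atoms) in place of a group of 3 heavy atoms (1 boron, 2 oxygen; no ring), on an aromatic carbon. The step is a 1.3-fold higher number from compound 1 to compound 2 (0.11 log units; within the scatter), so on that core the change left the read-out essentially where it was.

Compound 4 `CC1(C)OB(c2ccc(COc3cccc4ccc(C(=O)NCCCOc5no[n+]([O-])c5S(=O)(=O)c5ccccc5)nc34)cc2)OC1(C)C` is not yet measured. It carries the same change, now on the core of compound 3: a group of 9 heavy atoms (6 carbon, 1 boron, 2 oxygen; one five-membered non-aromatic ring with 3 hetero atoms) in place of a group of 3 heavy atoms (1 boron, 2 oxygen; no ring), on an aromatic carbon. Both times the change sits at the same place.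

Compound 4 is therefore expected to show a 1.3-fold higher number from compound 3 to compound 4 (0.11 log units; within the scatter), a step of about the earlier size, because a 1.3-fold higher number from compound 1 to compound 2 (0.11 log units; within the scatter) was seen for the same change on the other core. Compound 4 is estimated at 2200 nM, with a lower end of 1200 nM and an upper end of 4500 nM.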

Compound 4, half-maximal inhibitory concentration: 4890 nM
Compound 4: the middle estimate sits 2.2-fold (0.35 log units) below what was measured, and the stated range ends below it.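

In this assay, putting the group of 9 heavy atoms with its five-membered ring in place of the open group of 3 heavy atoms gives a 2.9-fold higher number from compound 3 to compound 4 (0.46 log units; beyond the scatter), so on the core of compound 3 this change has a real, though modest, cost in the read-out. The same swap on the core of compound 1 stays within the scatter, yet this alone does not show that the two cores respond differently. Set side by side, the two steps cannot be told apart, so the change may carry over from one core to the other, though two pairs cannot prove that it does: the same change on two cores in this assay, a 1.3-fold higher number (0.11 log units; within the scatter) from compound 1 to compound 2 and a 2.9-fold higher number (0.46 log units; beyond the scatter) from compound 3 to compound 4, 2.2-fold (0.35 log units) apart, within the scatter of two such steps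

The compounds shown leave open what other groups would do at this aromatic carbon, such as a carboxylic acid or an amine, and whether a plain hydrogen there would give a similar number. They also leave open whether the step would hold on a core with a longer chain.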